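A few compounds are considered here, and "the series" means these few. Any claim that something is new, unique, unknown or untested is made for them only; others in the source may bear on it.

Working notes on the series: in a functional assay on CLL cells (Homo sapiens) for cytotoxicity, read by MTT assay, with a stated time of 48 h (a lower number here means that less compound is needed, a higher number that more compound is needed for the effect), compound 1 (`C=C(CC)C(=O)c1ccc(OCC(=O)Nc2ccc(C(=O)O)cc2)c(Cl)c1Cl`) gives 5000 nM and compound 2 (`C=C(CC)C(=O)c1ccc(OCC(=O)Nc2ccc(C(C)=O)cc2)c(Cl)c1Cl`) gives 3900 nM. Among the measured compounds shown here, these two values lie within the scatter of each other, so compound 2 cannot be ranked apart from compound 1 on the numbers so far.

The next step leads to compound 3 (`C=C(CC)C(=O)c1ccc(OCC(=O)Nc2ccc(CC(=O)O)cc2)c(Cl)c1Cl`), which carries carboxymethyl in place of acetyl on an aromatic carbon, para to a large group: carboxymethyl in place of acetyl on an aromatic carbon. For the measured compounds named here, the one measured step that bears on this is a 1.3-fold lower number from compound 1 to compound 2 (0.11 log units; within the scatter), a change of methyl in place of hydroxy on a carbonyl carbon that stays within the scatter. Going by the values given here, no measured compound yet carries carboxymethyl, so this evidence is indirect. On the size of that single step, no change beyond the scatter is expected in this assay, and no direction is favoured with any confidence.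

The expected change is a 1.2-fold higher number from compound 2 to compound 3 (0.06 log units; within the scatter) in this series. For compound 3 the estimate is 4500 nM, with an expected range of 2000 nM to 10000 nM for the measurement.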

Compound 3, half-maximal effective concentration: 3200 nM
Compound 3: the middle estimate sits 1.4-fold (0.15 log units) above what was measured; the measured number falls inside the stated range.
By their numbers in this assay, from the lowest: compounds 3, 2 and 1 (each within the scatter of the next).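

At this position, on an aromatic carbon para to a large group, this assay now covers a third group, and carboxymethyl in place of acetyl gives a 1.2-fold lower number from compound 2 to compound 3 (0.09 log units; within the scatter), even though the entering group carries a hydrogen-bond donor that acetyl lacks. Carboxymethyl in place of carboxy gives a 1.6-fold lower number from compound 1 to compound 3 (0.19 log units; within the scatter), so compound 1, compound 2 and compound 3 cannot be ranked apart, and neither exchange at this position produces a readable change in this assay. Nothing on hand accounts for these numbers, and no reason can be offered for the flat result.

The three compounds leave open whether any group at this position can move the number beyond the scatter, for instance an amine, a hydroxymethyl, a primary amide or a longer carboxylic acid chain, or whether a plain hydrogen or methyl there would give a similar value. As far as these compounds go, they also leave open how much the rest of the shared core contributes, since all three keep it unchanged, so the effect of replacing a chlorine or the ethyl chain on the core remains unknown.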